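Extending the ether chain on the core toward a sulfone

The compounds below may be only part of what the source reports. "The series", "measured", "known", "first", "only" and "open" are said of these compounds alone.

Compound 1 `Cc1cc(O)ccc1-c1cccc(CNc2ccc(OCC(=O)O)c(F)c2)c1` gives 69.6 nM in a functional assay on CHO cells for agonist activity at Free fatty acid receptor 1 (Homo sapiens), read by FLIPR and calcium flux; on this read-out lower numbers stand for an effect already at smaller amounts and higher numbers for an effect only at larger amounts of compound.
Compound 2 `COCCOc1ccc(-c2cccc(CNc3ccc(OCC(=O)O)c(F)c3)c2)c(C)c1` gives 41.9 nM in this assay.
Compound 3 `Cc1cc(OCCO)ccc1-c1cccc(CNc2ccc(OCC(=O)O)c(F)c2)c1` gives 36.1 nM in this assay.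

Compound 3 has the lowest number of the three, but its distance to compound 2 and to compound 1 is within the scatter. Compound 4 `Cc1cc(OCCCS(C)(=O)=O)ccc1-c1cccc(CNc2ccc(OCC(=O)O)c(F)c2)c1` differs from compound 3 by (methylsulfonyl)methyl in place of hydroxy on a saturated chain carbon, two bonds along the chain from an oxygen on an aromatic ring. Within the data shown here, two measured steps bear on this position: a 1.9-fold lower number from compound 1 to compound 3 (0.29 log units; within the scatter) and a 1.2-fold lower number from compound 2 to compound 3 (0.06 log units; within the scatter), both within the scatter. Changes at this end of the chain have so far moved nothing beyond the scatter, so no step beyond it is expected in this assay for compound 4 either. Compound 4 is therefore estimated at 40 nM, between 14 nM and 115 nM, a step of a 1.1-fold higher number from compound 3 to compound 4 (0.04 log units; within the scatter).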

Compound 4, half-maximal effective concentration in the Free fatty acid receptor 1 assay: 45.6 nM
The estimate for compound 4 lay 1.1-fold (0.06 log units) below the measured number; the range from low to high includes it.
By their numbers in the Free fatty acid receptor 1 assay, from the lowest: compounds 3, 2, 4 and 1 (each within the scatter of the next).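

In the Free fatty acid receptor 1 assay compound 4, with the longer chain ending in a sulfone, gives 45.6 nM and stays within the scatter of all three earlier compounds (a 1.3-fold higher number from compound 3 to compound 4 (0.10 log units; within the scatter); a 1.1-fold higher number from compound 2 to compound 4 (0.04 log units; within the scatter); a 1.5-fold lower number from compound 1 to compound 4 (0.18 log units; within the scatter)). This position therefore takes (methylsulfonyl)methyl, a much larger group than hydroxy and one without a hydrogen-bond donor, with no step beyond the scatter. In a physicochemical assay for lipophilicity, read by HPLC, in phosphate buffer, measured as octanol-water partition, at pH 7.4, tested at 100 uM (on this read-out higher numbers stand for higher lipophilicity and lower numbers for lower lipophilicity), compound 3 gives 1.65 and compound 4 gives 1.59, and the same change also stays within the scatter (a number 0.06 log units lower from compound 3 to compound 4 (within the scatter)). Nothing measured here explains this result. The compounds shown leave open whether an amine or a carboxylic acid at this chain end, or a longer chain, would move the number beyond the scatter.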